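Shortening the chain end: compound 1 to compound 4

This account rests on a few compounds, and the source may have more. Where it says the series, first, only, none or still open, it means among the compounds named here.

The series shares one core, carried by compound 1 `CCC/N=C(/NC#N)NCCCCn1nc(-c2ccccc2)ccc1=O`, compound 2 `C/N=C(/NC#N)NCCCCCCn1nc(-c2ccccc2)ccc1=O` and compound 3 `CC/N=C(/NC#N)NCCCCCn1nc(-c2ccccc2)ccc1=O`. In a functional assay on the whole organism (stomach) with Rattus norvegicus as the target (on this read-out lower numbers stand for an effect already at smaller amounts and higher numbers for an effect only at larger amounts of compound), compound 1 gives > 100 mg/kg, which is a limit of the assay rather than a number. Compound 2 likewise reaches only a limit in this assay, at > 100 mg/kg. Compound 3 gives a measured number in this assay, 100 mg/kg. Going by the values given here, the single measured step, a number no higher from compound 2 to compound 3 (the limit leaves the size open), runs from a limit to a number, so its size stays open. On the numbers shown, compound 1 stands at the limit, a position it shares with compound 2, as noted in the limit of > 100 mg/kg in this assay, at which 2 of the 3 values shown sit.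

Compound 4 `CC/N=C(/NC#N)NCCCCn1nc(-c2ccccc2)ccc1=O` differs from compound 1 by hydrogen in place of methyl on a saturated chain carbon, two bonds along the chain from a double-bonded nitrogen. Among the compounds with values here, no measured step touches this position; the only step, between compound 2 and compound 3, changes another part of the chain and its size is not readable. The expectation for compound 4 rests on compound 1 sitting at > 100 mg/kg. It also rests on compound 3, which gives 100 mg/kg. Compound 4 is therefore expected to stay near the limit, with a number no higher from compound 1 to compound 4 (the limit leaves the size open) expected to be no larger than the scatter. Compound 4 is estimated at 100 mg/kg, between 50 mg/kg and 200 mg/kg.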

Compound 4, dose for half-maximal effect: 92 mg/kg
For compound 4 the middle estimate is 1.1-fold (0.04 log units) above the measured one, and the stated range covers the measured number.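

With compound 4, this position gains its first step with a readable floor: in this assay, hydrogen in place of methyl on a saturated chain carbon, two bonds along the chain from a double-bonded nitrogen, which is the same difference as propyl to ethyl, gives an at least 1.0-fold lower number from compound 1 to compound 4 (0.03 log units; that floor lies within the scatter) for this change. The value for compound 1 is a limit and not a number, so the step has only a floor, and no gain from propyl to ethyl is shown. What the change does show is that the ethyl end of compound 4 reads as a number on the butyl-length chain of the shared core, while the propyl end of compound 1 stays at a limit shared with another compound: the limit of > 100 mg/kg in this assay, at which 2 of the 4 values shown sit.

As far as these compounds go, how far compound 1 truly lies from compound 4 stays open, and so does the real size of this change. The chain ends shown stop at methyl, ethyl and propyl, so the effect of a butyl group, or of a chain end carrying an amine or a carboxylic acid, remains unknown from these compounds.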